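Butyl in Place of Isopropyl: What Three Compounds Suggest

The source may report more compounds than this note shows. Statements on the series, on what has been measured and on what is new or still open speak of the compounds shown alone.

Compound 1 `CCCCn1cnc2c(Nc3cccc(Cl)c3)nc(NCOCc3ccc(/C=C/C(=O)Nc4ccccc4N)cc3)nc21`: 30.4%
Compound 2 `CC(C)n1cnc2c(Nc3ccccc3)nc(NCOCc3ccc(/C=C/C(=O)Nc4ccccc4N)cc3)nc21`: 40.8%
Compound 3 `CC(C)n1cnc2c(Nc3cccc(Cl)c3)nc(NCOCc3ccc(/C=C/C(=O)Nc4ccccc4N)cc3)nc21`: 49.9%

Of the compounds shown here, three have been measured in a functional assay on HepG2 cells (Homo sapiens) for antiproliferative activity, read by CCK-8 assay, with a stated time of 72 h, tested at 8 uM; on this read-out higher numbers stand for a stronger effect at the one concentration tested and lower numbers for a weaker effect. Compound 2 stands second highest of the three. Its nearest neighbour is compound 3, with a number 9.1 percentage points higher from compound 2 to compound 3 (within the scatter), while compound 1 lies beyond the scatter on the low side.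

Compound 4 `CCCCn1cnc2c(Nc3ccccc3)nc(NCOCc3ccc(/C=C/C(=O)Nc4ccccc4N)cc3)nc21` has not yet been measured. It differs from compound 2 in one place: butyl in place of isopropyl on an aromatic nitrogen.

Among the compounds with values here, one measured step bears on this change directly, though run the other way: a number 19.5 percentage points higher from compound 1 to compound 3 (beyond the scatter), where the two compounds share a chloro-substituted aniline. Turning that step around, butyl entering for isopropyl would be expected to cost roughly the same amount. The step from compound 2 to compound 3 does not concern the alkyl group and offers no further guide.

Compound 4 is therefore expected to fall below compound 2 by an amount beyond the scatter, with an estimated a number 18.8 percentage points lower from compound 2 to compound 4 (beyond the scatter). The estimate for compound 4 is 22%, within a range from 9% to 35%.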

Compound 4, a percentage reported as inhibition, at one concentration (the size of the read-out at that concentration, not a potency): 59.3%
Compound 4: the middle estimate sits 37.3 percentage points below what was measured; measured number outside the range, above it.
By their numbers in this assay, from the lowest: compound 1; then compounds 2, 3 and 4 (each within the scatter of the next, the first and the last beyond it).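

At this aromatic nitrogen, the effect of butyl in place of isopropyl depends on the other site of change: with hydrogen on the aromatic carbon the exchange gives a number 18.5 percentage points higher from compound 2 to compound 4 (beyond the scatter), the opposite direction to the step seen with chloro, so the earlier step does not carry over from one core to the other: the same change on two cores in this assay, a number 19.5 percentage points higher (beyond the scatter) from compound 1 to compound 3 and a number 18.5 percentage points lower (beyond the scatter) from compound 4 to compound 2, 38 percentage points apart, beyond the scatter of two such steps The exchange of chloro and hydrogen depends in turn on the alkyl group: with butyl on the nitrogen, hydrogen in place of chloro gives a number 28.9 percentage points higher from compound 1 to compound 4 (beyond the scatter), whereas with isopropyl the same pair of compounds had differed only within the scatter: the same change on two cores in this assay, a number 9.1 percentage points higher (within the scatter) from compound 2 to compound 3 and a number 28.9 percentage points lower (beyond the scatter) from compound 4 to compound 1, 38 percentage points apart, beyond the scatter of two such steps Across these four compounds, then, the two sites do not act as separate, additive steps, and neither change has a single size that could be transferred to a new compound.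

The compounds shown leave open whether a longer chain such as hexyl, or a chain ending in an amine, would follow the trend with hydrogen or the one with chloro on the aromatic carbon. They also leave open whether a group such as bromo or methoxy in place of chloro would show the same dependence, and how these numbers at one concentration relate to potency.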